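The compounds below may be only part of what the source reports. "The series", "measured", "known", "first", "only" and "open" are said of these compounds alone.

Measured so far in a functional assay on HEK293T cells for agonist activity at histamine H2 receptor (Homo sapiens), read by beta-arrestin recruitment; on this read-out higher numbers stand for larger maximal responses and lower numbers for smaller maximal responses:
- compound 1, `Cc1nc(N)sc1CCCN/C(N)=N/C(=O)Nc1ccccc1`, gives 0.25
- compound 2, `Cc1nc(N)sc1CCCN/C(N)=N/C(=O)NC1CCCCC1`, gives 0.43

Among the measured compounds shown here, compound 2 stands highest of the two numbers measured; its nearest neighbour is compound 1, and the single measured step, a number 0.18 higher from compound 1 to compound 2 (beyond the scatter), separates them beyond the scatter. Compound 3, `CCCCCNC(=O)/N=C(\N)NCCCc1sc(N)nc1C`, is not yet measured. Its difference from compound 2 is pentyl in place of cyclohexyl on an amide-type nitrogen. For the measured compounds named here, the only measured step bears on this change loosely: it swapped a ring for another ring at the same amide-type nitrogen, whereas here a ring gives way to a chain, so it offers no direct guide to the direction. The step is expected to be small, likely within the scatter, leaning slightly downward. Compound 3 is therefore expected to give 0.4, with a range from 0.25 to 0.55. The estimated step from compound 2 is a number 0.030 lower from compound 2 to compound 3 (within the scatter).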

Compound 3, intrinsic activity: the largest response reached, as a fraction of the reference agonist's: 0.15
Estimate against measurement, compound 3: 0.25 above; measured number outside the range, below it.
By their numbers in this assay, from the lowest: compounds 3 and 1 (each within the scatter of the next); then compound 2.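

In this assay, the earlier ring-for-ring swap left open what a chain would do at this amide-type nitrogen, and replacing the cyclohexyl ring of compound 2 with pentyl brings a number 0.28 lower from compound 2 to compound 3 (beyond the scatter) in the maximal response. Set against the phenyl group, the same chain gives a number 0.10 lower from compound 1 to compound 3 (within the scatter) and so does not separate from it, leaving cyclohexyl as the only one of the three groups whose value stands apart from both others. Nothing available explains why cyclohexyl differs from the other two groups.

The compounds shown leave open whether a carbon ring of another size, such as cyclopentyl or cycloheptyl, would keep the response of compound 2. They also leave open whether a longer chain, such as heptyl, would stay level with pentyl or move away from it.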